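The source may report more compounds than this note shows. Statements on the series, on what has been measured and on what is new or still open speak of the compounds shown alone.

Three compounds of this series have numbers in a functional assay on MT4 cells (Homo sapiens) for antiproliferative activity, read by MTT assay, with a stated time of 96 h; a higher number here means that more compound is needed for the effect, a lower number that less compound is needed. Compound 1 `CCOC(=O)/C(=C/c1c[nH]c2ccccc12)C(=O)c1ccc([N+](=O)[O-])cc1` gives 100000 nM in this assay. Compound 3 `Cc1[nH]c2ccccc2c1C=C(C#N)C#N` gives 56000 nM in this assay. Compound 2 `N#C/C(=C\c1c(-c2ccccc2)[nH]c2ccccc12)C(=O)c1ccccc1` gives 500 nM in this assay, the lowest of the three numbers; the gap to compound 3, its nearest neighbour, and the wider gap to compound 1 both lie well beyond the scatter, so compound 2 needs the least compound for the effect of the three.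

The next compound, compound 4 `N#C/C(=C\c1c(-c2ccccc2)[nH]c2ccccc12)S(=O)(=O)c1ccccc1`, differs from compound 2 in one place: phenylsulfonyl in place of benzoyl on a double-bonded chain carbon bound to a double-bonded chain carbon and a triple-bonded carbon. Going by the values given here, no pair of measured compounds differs in one place, so no measured step bears directly on this change; the rest of the structure is carried over from compound 2 unchanged.

With nothing measured to anchor it, the step in this assay is expected to be modest, most likely a small rise that may just pass the scatter: a 3.0-fold higher number from compound 2 to compound 4 (0.48 log units; beyond the scatter). Compound 4 is estimated at 1500 nM in this assay, with a range from 300 nM to 8000 nM.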

Compound 4, half-maximal effective concentration: 400 nM
Beside the measured number, compound 4's estimate is 3.8-fold (0.57 log units) above it; the measured number falls inside the stated range.
By their numbers in this assay, from the lowest: compounds 4 and 2 (each within the scatter of the next); then compounds 3 and 1 (each within the scatter of the next).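

On the double-bonded chain carbon bound to a double-bonded chain carbon and a triple-bonded carbon, phenylsulfonyl in place of benzoyl gives a 1.3-fold lower number from compound 2 to compound 4 (0.10 log units; within the scatter) in this assay. Going by these compounds alone, this is the first one-place step, and it shows that the position takes this exchange with no change that can be told from the scatter: benzoyl is not required here to keep a number of this size. No measurement shown explains why the two groups match at this position.

Going by these compounds, whether the match holds for a group without a phenyl ring, such as a carboxylic acid or an amine, remains open. The compounds shown also give no one-place step anywhere else in the structure, so the contribution of the remaining parts of compound 2 is still unknown.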